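This account rests on a few compounds, and the source may have more. Where it says the series, first, only, none or still open, it means among the compounds named here.

Of the compounds shown here, three sharing one core have been measured in a functional assay on cells (T-cell, Homo sapiens) for inhibition; on this read-out lower numbers stand for stronger inhibition and higher numbers for weaker inhibition. Compound 1 `COc1ccc(-c2cnc3nc(N)nc(N4CCN(C(=O)NCc5ccc(F)cc5)CC4)c3n2)cc1OC` gives 37 nM in this assay. Compound 2 `COc1ccc(-c2cnc3nc(N)nc(N4CCN(c5cc(Cl)cc(Cl)c5)CC4)c3n2)cc1OC` gives 3400 nM in this assay, and compound 3 `CCOc1ccc(-c2cnc3nc(N)nc(OC(C)C)c3n2)cc1`, which carries a different group on the core, gives 10000 nM in this assay. Among these three numbers compound 2 holds the second highest place: its nearest neighbour is compound 3, its most distant is compound 1. For the measured compounds named here, the only step joining two measured compounds that differ in a single place is a 92-fold higher number from compound 1 to compound 2 (1.96 log units; beyond the scatter), a large step in which a 3,5-dichlorophenyl replaces a (4-fluorobenzyl)carbamoyl on an amine nitrogen in a ring.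

Compound 4 `COc1ccc(-c2cnc3nc(N)nc(N4CCN(c5ccc(F)cc5)CC4)c3n2)cc1OC` has not yet been measured. It differs from compound 2 in one place: 4-fluorophenyl in place of 3,5-dichlorophenyl on an amine nitrogen in a ring. The step of a 92-fold higher number from compound 1 to compound 2 (1.96 log units; beyond the scatter) bears on this same position, but it swapped a carbamoyl-linked group for a directly attached aromatic ring, whereas compound 4 keeps a directly attached aromatic ring and only changes that ring. Going by the values given here, no measured step isolates such a swap, so the direction is uncertain and the expected change is modest, a 1.7-fold lower number from compound 2 to compound 4 (0.23 log units; within the scatter), in this assay. Compound 4 is therefore estimated to give 2000 nM in this assay, with a likely range from 500 nM to 8000 nM.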

Compound 4, half-maximal inhibitory concentration: 100 nM
For compound 4 the middle estimate is 20-fold (1.30 log units) above the measured one, outside the stated range (below it).
By their numbers in this assay, from the lowest: compound 1; then compound 4; then compound 2; then compound 3.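

In this assay, a ring attached directly to the amine nitrogen does not by itself bring a high number: with 4-fluorophenyl in place of 3,5-dichlorophenyl, the position shows a 34-fold lower number from compound 2 to compound 4 (1.53 log units; beyond the scatter), a large step from changing only what the ring carries. The earlier 92-fold higher number from compound 1 to compound 2 (1.96 log units; beyond the scatter) could have been read as the price of losing the (4-fluorobenzyl)carbamoyl group, yet replacing that group with 4-fluorophenyl gives only a 2.7-fold higher number from compound 1 to compound 4 (0.43 log units; beyond the scatter), which is modest though beyond the scatter, so most of the earlier rise goes with the 3,5-dichlorophenyl ring rather than with losing the carbamoyl group. No evidence on the reason for the gap between these two rings is at hand.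

The compounds shown do not separate the removal of the two chlorines from the arrival of the fluorine, and a plain phenyl ring or a phenyl ring with a single chlorine at this position would pull those two changes apart. From the compounds shown here alone, it also remains open how this position responds to a group with no aromatic ring, such as a simple acetyl or methyl on the same nitrogen.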